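The source may hold more compounds than are shown below. What is called first, only, known or untested is meant among the compounds shown, and "the series" means these compounds.

Compound 1 `COc1cc(-c2nnc(SCc3ccccc3)n2/N=C/c2ccccc2)cc(OC)c1OC`, compound 2 `COc1cc(-c2nnc(SCc3ccccc3Cl)n2/N=C/c2ccccc2)cc(OC)c1OC` and compound 3 `COc1ccc(/C=N/n2c(SCc3ccccc3Cl)nnc2-c2cc(OC)c(OC)c(OC)c2)c(OC)c1` share one core. In a functional assay on MKN-45 cells (Homo sapiens) for cytotoxicity, read by MTT assay, with a stated time of 48 h (a lower number here means a stronger inhibitor, a higher number a weaker inhibitor), compound 1 gives only a limit, > 200000 nM. Compound 2 likewise gives only a limit in this assay, > 200000 nM. Compound 3 also returns a limit in this assay, > 200000 nM. The change hydrogen in place of chloro on an aromatic carbon therefore reads as a step that the two limits leave unreadable from compound 2 to compound 1, because of the limit of > 200000 nM in this assay, at which 3 of the 3 values shown sit. The cores of compound 2 and compound 3 differ by 2,4-dimethoxyphenyl in place of phenyl on a carbon with a double bond to nitrogen, and that step is a step that the two limits leave unreadable from compound 2 to compound 3, again because of the limit of > 200000 nM in this assay, at which 3 of the 3 values shown sit. Compound 4 `COc1ccc(/C=N/n2c(SCc3ccccc3)nnc2-c2cc(OC)c(OC)c(OC)c2)c(OC)c1` carries the first change onto the core of compound 3: hydrogen in place of chloro on an aromatic carbon, the same change at the same place as in compound 1. Beside a step that the two limits leave unreadable from compound 2 to compound 1 the expected step is a number no higher from compound 3 to compound 4 (the limit leaves the size open), an expectation resting on (the limit of > 200000 nM in this assay, at which 3 of the 3 values shown sit). Compound 4 is thus expected to give a limit as well, estimated near 200000 nM, between 100000 nM and 400000 nM.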

Compound 4, half-maximal inhibitory concentration: 49000 nM
Compound 4: middle estimate off by 4.1-fold (0.61 log units), on the high side; measured number below the stated range.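

In this assay, hydrogen in place of chloro on the core of compound 3 gives an at least 4.0-fold lower number from compound 3 to compound 4 (0.61 log units; beyond the scatter), while the same change on the core of compound 2 and the step from compound 2 to compound 3 cannot be read. With benzylsulfanyl held constant, 2,4-dimethoxyphenyl in place of phenyl gives an at least 4.0-fold lower number from compound 1 to compound 4 (0.61 log units; beyond the scatter), so a number appears only where both changes meet, in compound 4. This does not show that the chloro change carries from one core to the other, and the full size of each step stays open: the limit of > 200000 nM in this assay, at which 3 of the 4 values shown sit.

The compounds shown leave open whether an amine or a carboxylic acid in place of the chloro would keep a number in this assay. Also open, as far as these compounds go, is how a longer chain in place of benzyl would read on the core of compound 4.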